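From 1-methylcyclopropyl to cyclopropylmethyl on a shared core

The source may report more compounds than this note shows. Statements on the series, on what has been measured and on what is new or still open speak of the compounds shown alone.

Of the compounds shown here, three with one shared core have been measured in a physicochemical assay for solubility, using the shake flask method, in simulated intestinal fluid, measured as kinetic solubility, with a stated time of 20 h, at pH 6.5; a higher number here means a more soluble compound, a lower number a less soluble compound. Compound 1 `FC(F)(F)c1ccc(Nc2cc3[nH]c(C4CCOC4)nc3cn2)nc1`, which carries oxolan-3-yl, gives 180000 nM. Compound 2 `FC(F)(F)c1ccc(Nc2cc3[nH]c(C4CC4)nc3cn2)nc1`, which carries cyclopropyl, gives 123000 nM. Compound 3 `CC1(c2nc3cnc(Nc4ccc(C(F)(F)F)cn4)cc3[nH]2)CC1`, which carries 1-methylcyclopropyl, gives 179000 nM. Compound 3 thus stands within the scatter of both of the others, as shown by a 1.0-fold lower number from compound 1 to compound 3 (0.00 log units; within the scatter) and by a 1.5-fold higher number from compound 2 to compound 3 (0.16 log units; within the scatter).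

The next compound, compound 4 `FC(F)(F)c1ccc(Nc2cc3[nH]c(CC4CC4)nc3cn2)nc1`, has not yet been measured. It has cyclopropylmethyl in place of 1-methylcyclopropyl on an aromatic carbon, and its difference from compound 3 comes to cyclopropylmethyl in place of 1-methylcyclopropyl on an aromatic carbon.

Among the compounds with values here, no measured step makes this exact exchange, so the evidence is indirect. Three steps change the group on that same aromatic carbon: a 1.5-fold lower number from compound 1 to compound 2 (0.17 log units; within the scatter), a 1.0-fold lower number from compound 1 to compound 3 (0.00 log units; within the scatter) and a 1.5-fold higher number from compound 2 to compound 3 (0.16 log units; within the scatter). All three stay within the scatter, and that includes the exchange of oxolan-3-yl for a group of carbon only in compound 2 and compound 3. Nothing in these three compounds points to a direction for the new exchange. The expected outcome is a 1.2-fold lower number from compound 3 to compound 4 (0.06 log units; within the scatter), an estimated step that does not go beyond the scatter. Compound 4 is estimated at 155000 nM, with an expected range of 80000 nM to 300000 nM.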

Compound 4, solubility: 156000 nM
Beside the measured number, compound 4's estimate is 1.0-fold (0.00 log units) below it; low and high end bracket the measured number.
By their numbers in this assay, from the lowest: compounds 2, 4, 3 and 1 (each within the scatter of the next).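

In this assay, exchanging 1-methylcyclopropyl for cyclopropylmethyl, two groups with the same atoms joined differently, stays within the scatter (a 1.1-fold lower number from compound 3 to compound 4 (0.06 log units; within the scatter)). Rejoining these atoms on an aromatic carbon between two ring nitrogen atoms therefore does not take the reading outside the scatter, and cyclopropylmethyl also stays within the scatter of the other two groups at this position (a 1.3-fold higher number from compound 2 to compound 4 (0.10 log units; within the scatter)) and (a 1.2-fold lower number from compound 1 to compound 4 (0.06 log units; within the scatter)). All four groups shown here, oxolan-3-yl among them, thus give readings that cannot be told apart at this position, and no measurement at hand gives a reason for this.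

The compounds shown leave open whether this position would stay as insensitive with a group of another kind, such as an amine or a carboxylic acid, or with a longer chain than cyclopropylmethyl. They also leave open whether the same would hold on a shared core in which the trifluoromethyl group is replaced by another group, such as a nitrile.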